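Reverse amide at the indole five-position of the acylsulfonamide series

The source may report more compounds than this note shows. Statements on the series, on what has been measured and on what is new or still open speak of the compounds shown alone.

Three members of the series carry numbers in a functional assay on trachea for agonist activity at cysteinyl leukotriene receptor (Homo sapiens); on this read-out higher numbers stand for weaker inhibition and lower numbers for stronger inhibition. Compound 1 `CCCCOC(=O)Nc1ccc2ccn(Cc3ccc(C(=O)O)cc3OC)c2c1` gives 155 nM. Among the measured compounds shown here, compound 2 `COc1cc(C(=O)O)ccc1Cn1ccc2ccc(NC(=O)OC3CCCC3)cc21` gives 15.7 nM, and the step of a 9.9-fold lower number from compound 1 to compound 2 (0.99 log units; beyond the scatter) is the only single-point change measured so far. Compound 3 `COc1cc(C(=O)NS(=O)(=O)c2ccccc2C)ccc1Cc1cn(C)c2ccc(NC(=O)CC3CCCC3)cc12` gives 24.5 nM; it stands second of the three numbers, within the scatter of compound 2 and well apart from compound 1.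

Compound 4 `COc1cc(C(=O)NS(=O)(=O)c2ccccc2C)ccc1Cc1cn(C)c2ccc(C(=O)NCC3CCCC3)cc12` differs from compound 3 by (cyclopentylmethyl)carbamoyl in place of ((cyclopentylmethyl)carbonyl)amino on an aromatic carbon. For the measured compounds named here, no measured step bears on an inversion of this kind: the one step in hand, from compound 1 to compound 2, swaps a chain for a ring on a carbamate oxygen and says nothing about turning an acylamino group into a carbamoyl group. The atom count, donor count and acceptor count do not change. Going by the values given here, with no relevant precedent, the expected step of a 1.2-fold higher number from compound 3 to compound 4 (0.09 log units; within the scatter) is taken as none beyond the scatter, with a wide band to either side. Compound 4 is therefore estimated at 30 nM, in the range 8 nM to 120 nM.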

Compound 4, antagonist equilibrium constant: 4.28 nM
Estimate against measurement, compound 4: 7.0-fold (0.85 log units) above; the whole stated range lies above it.
By their numbers in this assay, from the lowest: compound 4; then compounds 2 and 3 (each within the scatter of the next); then compound 1.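

On this assay the direction of the amide at this aromatic carbon matters, with a 5.7-fold lower number from compound 3 to compound 4 (0.76 log units; beyond the scatter) as the two side chains swap the places of carbonyl and nitrogen while keeping the same atoms. Among the compounds shown here, the earlier step touched only the group on a carbamate oxygen, so this is the first sign that the way the side chain joins the ring counts, and not just what sits at its far end. Nothing in hand accounts for the stronger inhibition of the carbamoyl arrangement.

Going by these compounds, the finding rests on a single pair, so it is open whether the preference for the carbamoyl link survives with cyclohexylmethyl or a longer chain in place of cyclopentylmethyl. On these data alone, it is equally open whether it holds with a carboxylic acid in place of the acylsulfonamide.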